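The compounds below may be only part of what the source reports. "The series", "measured", "known", "first", "only" and "open" are said of these compounds alone.

Compound 1 `C[C@@H]1CCCN1c1c(C#N)c2c(N)nc(Nc3cn[nH]c3)nc2n1C` gives 6 nM in an assay on isolated protein for inhibition of Leucine-rich repeat serine/threonine-protein kinase 2 variant G2019S (Homo sapiens), read by TR-FRET and LanthaScreen, with stated times of 50 min and 30 min, in the presence of a further agent that is not named here; a lower number here means a stronger inhibitor, a higher number a weaker inhibitor; compound 2 `C[C@@H]1CCCN1c1c(C#N)c2c(N)nc(Nc3cn(C)nc3Cl)nc2n1C` gives 21 nM; compound 3 `C[C@@H]1CCCN1c1c(C#N)c2c(N)nc(N)nc2n1C` gives 217 nM.

Compound 3 stands highest of the three numbers; its neighbour is compound 2, and compound 1 lies furthest from it. Compound 4 `C[C@@H]1CCCN1c1c(C#N)c2c(N)nc(Nc3cnn(C)c3)nc2n1C` differs from compound 3 by 1-methyl-1H-pyrazol-4-yl in place of hydrogen on a nitrogen on an aromatic ring. Among the compounds with values here, two measured steps bear on this change in the reverse direction: a 36-fold higher number from compound 1 to compound 3 (1.56 log units; beyond the scatter) and a 10-fold higher number from compound 2 to compound 3 (1.01 log units; beyond the scatter). The comparison a 3.5-fold higher number from compound 1 to compound 2 (0.54 log units; beyond the scatter) shows that what sits on the pyrazole matters modestly. A large fall in the number is therefore expected for compound 4, an estimated 22-fold lower number from compound 3 to compound 4 (1.34 log units; beyond the scatter). Compound 4 is estimated at 10 nM, within 4 nM to 30 nM.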

Compound 4, half-maximal inhibitory concentration: 5 nM
The estimate for compound 4 lay 2.0-fold (0.30 log units) above the measured number; low and high end bracket the measured number.
By their numbers in this assay, from the lowest: compounds 4 and 1 (each within the scatter of the next); then compound 2; then compound 3.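

In this assay, methyl in place of hydrogen on the aromatic nitrogen of the pyrazole makes no difference beyond the scatter (a 1.2-fold lower number from compound 1 to compound 4 (0.08 log units; within the scatter)), so the free hydrogen there is not needed in this pair. The 1-methyl-1H-pyrazol-4-yl group on the amino nitrogen accounts for a large step (a 43-fold lower number from compound 3 to compound 4 (1.64 log units; beyond the scatter)). Compound 4 also isolates the chloro, since hydrogen in its place gives a modest step (a 4.2-fold lower number from compound 2 to compound 4 (0.62 log units; beyond the scatter)).

On these data alone, whether a longer chain, or one ending in an amine or a carboxylic acid, would be tolerated on that pyrazole nitrogen stays open. No evidence on the cause of these steps is at hand.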